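Series notes: side chain on the charged core, compound 3

The compounds below may be only part of what the source reports. "The series", "measured", "known", "first", "only" and "open" are said of these compounds alone.

Compound 1 `c1ccc(Cn2c3ccccc3[n+]3nc4c(cc23)-c2cccc3cccc-4c23)cc1` carries a benzyl group on the aromatic nitrogen of the shared core. Within the data shown here, in a functional assay on HT-29 cells (Homo sapiens) for inhibition, with a stated time of 72 h (a higher number here means that more compound is needed for the effect, a lower number that less compound is needed), compound 1 gives 1500 nM, the lowest of the two numbers measured so far; compound 2 `c1ccc(Cn2c3ccccc3[n+]3nc4c(c(-c5ccccc5)c23)-c2cccc3cccc-4c23)cc1` gives 3700 nM, and the step of a 2.5-fold higher number from compound 1 to compound 2 (0.39 log units; beyond the scatter) corresponds to phenyl in place of hydrogen on an aromatic carbon. Compound 3 `NCCNC(=O)Cn1c2ccccc2[n+]2nc3c(cc12)-c1cccc2cccc-3c12` differs from compound 1 by (2-aminoethyl)carbamoyl in place of phenyl on a saturated chain carbon bound to an aromatic nitrogen. Among the measured compounds shown here, no measured step touches this chain: the only known step, from compound 1 to compound 2, changes an aromatic carbon of the core and not the substituent on the aromatic nitrogen, so it gives no direction for compound 3. With nothing to anchor a shift, the expected step of no change at the digits printed from compound 1 to compound 3 (within the scatter) is none beyond the scatter, held with a wide range. Compound 3 is therefore estimated at 1500 nM in this assay, between 350 nM and 6500 nM.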

Compound 3, half-maximal effective concentration: > 100000 nM
Compound 3: only a limit was reported; the forecaster's own chance of this, stated with the estimate: 10%; middle value at least 66-fold (1.82 log units) from the limit.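

Unlike the core carbon changed in a 2.5-fold higher number from compound 1 to compound 2 (0.39 log units; beyond the scatter), the saturated chain carbon bound to an aromatic nitrogen carries a change with a far greater reach in this assay: benzyl to ((2-aminoethyl)carbamoyl)methyl gives an at least 66-fold higher number from compound 1 to compound 3 (1.82 log units; beyond the scatter). Compound 3 gives > 100000 nM, which is a limit and not a number, so the step has a floor but no measured size. One value in the set has this form: the limit of > 100000 nM in this assay, at which 1 of the 3 values shown sits.

Still open, from the compounds shown here alone, is which part of the change carries the step: the loss of the phenyl ring, the arrival of the carbonyl, or the terminal amine. A plain acetamide without the amine, a carboxylic acid at the chain end, or a fluorobenzyl group would help separate these parts.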